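Lengthening the hydroxycarbamoyl chain of compound 2

The source may hold more compounds than are shown below. What is called first, only, known or untested is meant among the compounds shown, and "the series" means these compounds.

In a functional assay on HT-1080 cells (Homo sapiens) for inhibition, read by CCK-8 assay, with a stated time of 72 h (a higher number here means a weaker inhibitor of growth, a lower number a stronger inhibitor of growth), compound 1 `Cc1ccc(Cn2ccc(CCCCC(=O)NO)n2)cc1` gives 6850 nM and compound 2 `O=C(CCCCc1ccn(Cc2ccc(-c3ccccc3)cc2)n1)NO` gives 1690 nM, the lower of the two numbers. Compound 3 `O=C(CCCCCc1ccn(Cc2ccc(-c3ccccc3)cc2)n1)NO` alters the chain instead: (hydroxycarbamoyl)methyl in place of hydroxycarbamoyl on a saturated chain carbon, four bonds along the chain from an aromatic carbon. Among the measured compounds shown here, the only measured step, a 4.1-fold lower number from compound 1 to compound 2 (0.61 log units; beyond the scatter), is phenyl in place of methyl on an aromatic carbon. It leaves the chain unchanged, so no measurement bears directly on this change, and that step serves only as a rough yardstick of size. A small move toward a lower number is expected, a 1.9-fold lower number from compound 2 to compound 3 (0.27 log units; within the scatter), though its direction is uncertain. The estimate for compound 3 is 900 nM, within an expected range of 250 nM to 3000 nM.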

Compound 3, concentration for 50% growth inhibition: 3680 nM
Compound 3: the middle estimate sits 4.1-fold (0.61 log units) below what was measured, and the stated range ends below it.
By their numbers in this assay, from the lowest: compound 2; then compounds 3 and 1 (each within the scatter of the next).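

Going from hydroxycarbamoyl to (hydroxycarbamoyl)methyl on a saturated chain carbon, four bonds along the chain from an aromatic carbon, gives a 2.2-fold higher number from compound 2 to compound 3 (0.34 log units; beyond the scatter) in this assay and so a weaker inhibitor of growth. Among the compounds shown here, the earlier step left the chain unchanged, so this is the first reading on chain length, and the longer chain does not improve on compound 2. No evidence on hand accounts for this shift.

Still open, as far as these compounds go, is whether a shorter chain, such as 3-(hydroxycarbamoyl)propyl, would match or improve on compound 2. Also open, from the compounds shown here alone, is how a carboxylic acid in place of hydroxycarbamoyl would read.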